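Swapping Fluoro for Methoxy in a Weak Growth Inhibitor

A few compounds are considered here, and "the series" means these few. Any claim that something is new, unique, unknown or untested is made for them only; others in the source may bear on it.

Two related compounds have been tested so far in a functional assay on K562 cells (Homo sapiens) for inhibition, read by sulforhodamine B assay, with a stated time of 48 h; a lower number here means a stronger inhibitor of growth, a higher number a weaker inhibitor of growth. In two separate entries, compound 1 `CCOC(=O)c1nn(-c2ccccc2)c(-c2ccc(F)cc2)c1CNC(C)(C)C` gives 75700 nM; 161000 nM (2 entries) in this test, so a number can be reported for it, though only at high concentrations.

Compound 2 `CC(C)(C)NCc1c(C(=O)O)nn(-c2ccccc2)c1-c1ccc(F)cc1` has no such number. Compound 2 is recorded as > 680000 nM and this figure is a limit of the assay, not a measured value. Its place on the scale is therefore known only through that limit.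

Compound 3 `COc1ccc(-c2c(CNC(C)(C)C)c(C(=O)O)nn2-c2ccccc2)cc1` differs from compound 2 at one place on the molecule: methoxy in place of fluoro on an aromatic carbon is the counted change. In words, 4-fluorophenyl becomes 4-methoxyphenyl, with methoxy in place of fluoro on an aromatic carbon. Going by the values given here, no measured pair in this small set shows what such a swap does. The expected change, an at least 1.0-fold lower number from compound 2 to compound 3 (0.01 log units; that floor lies within the scatter), is therefore none beyond the usual scatter. This expectation starts from compound 2 at > 680000 nM and that starting point is again a limit. Compound 3 is expected to read near 660000 nM in this assay with an estimated range from 300000 nM to 1300000 nM, and it may well be reported only as a limit.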

Compound 3, concentration for 50% growth inhibition: > 659000 nM
Compound 3 gave a limit, no number; the forecaster's own chance of this, stated with the estimate: 75%; the middle value lies beyond the limit too.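

Going by these compounds alone, compound 2 and compound 3 are both recorded only as limits in this assay, not as numbers, and no step between them can be read. The compounds shown leave open what methoxy in place of fluoro on an aromatic carbon does to growth inhibition, in either direction and at any size.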